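A few compounds are considered here, and "the series" means these few. Any claim that something is new, unique, unknown or untested is made for them only; others in the source may bear on it.

Working notes on the series. Compound 1 `CCCOc1nc(N)nc2c1ncn2/C=C1/CC1(CO)CO` carries a propoxy group on the shared core. In an ADME assay on MOLT-3 cells (Homo sapiens) for cytotoxicity, with a stated time of 7 days (a higher number here means that more compound is tolerated, a lower number that less compound is tolerated), compound 1 gives only a limit, > 20000 nM. Compound 2 `CCCCNc1nc(N)nc2c1ncn2/C=C1/CC1(CO)CO` differs by butylamino in place of propoxy on an aromatic carbon. In this assay compound 2 likewise reaches only a limit, > 20000 nM. The step that the two limits leave unreadable from compound 1 to compound 2 is not readable in size, since both values sit at the limit of > 20000 nM in this assay, at which 2 of the 2 values shown sit. Compound 2 thus stands at the limit of this assay, with no number to place it. Compound 3 `CCCCCCSc1nc(N)nc2c1ncn2/C=C1/CC1(CO)CO` is not yet measured; it differs from compound 2 by hexylsulfanyl in place of butylamino on an aromatic carbon. Going by the values given here, the one measured step bears on this change, and its size cannot be read, so no step beyond the scatter can be expected in either direction. For compound 3 the step that the limit leaves unreadable from compound 2 to compound 3 is expected to land again at the limit. Compound 3 is accordingly estimated at 30000 nM, within 10000 nM to 100000 nM.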

Compound 3, half-maximal cytotoxic concentration: > 20000 nM
Compound 3: a limit, no number; the forecaster's own chance of this, stated with the estimate: 70%; the middle value lies beyond the limit too.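

In this assay compound 3 gives > 20000 nM and this is a limit, not a number. Going by these compounds alone, no step among compound 1, compound 2 and compound 3 can therefore be read: the limit of > 20000 nM in this assay, at which 3 of the 3 values shown sit. The compounds shown leave open whether the propoxy, butylamino and hexylsulfanyl groups differ at all in tolerated concentration.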